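This account rests on a few compounds, and the source may have more. Where it says the series, first, only, none or still open, it means among the compounds named here.

In a functional assay on HUVEC cells (Homo sapiens), read by BrdU incorporation, with a stated time of 72 h (a lower number here means a stronger inhibitor, a higher number a weaker inhibitor), two compounds have been measured so far. Compound 1 `Cc1ccc2cc(/C=C/C(=O)c3ccc(I)s3)c(Cl)nc2c1` gives 135 nM, and compound 2 `Cc1ccc2nc(Cl)c(/C=C/C(=O)c3sccc3Cl)cc2c1` gives 37.5 nM, the lower of the two numbers, with a gap beyond the usual scatter. Compound 3 `Cc1csc(C(=O)/C=C/c2cc3cc(C)ccc3nc2Cl)c1` differs from compound 2 in a single group: 4-methylthiophen-2-yl in place of 3-chlorothiophen-2-yl on a carbonyl carbon. In words, it carries 4-methylthiophen-2-yl in place of 3-chlorothiophen-2-yl on a carbonyl carbon. Among the measured compounds shown here, no measured pair shows this change on its own, so the only guide is the span from compound 2 at 37.5 nM to compound 1 at 135 nM. A moderate loss of strength in this assay is expected, with a higher number, and the estimated change is a 2.1-fold higher number from compound 2 to compound 3 (0.33 log units; beyond the scatter). Compound 3 is expected at 80 nM, with an estimated range from 25 nM to 250 nM.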

Compound 3, half-maximal inhibitory concentration: 106 nM
Estimate against measurement, compound 3: 1.3-fold (0.12 log units) below; the range from low to high includes it.
By their numbers in this assay, from the lowest: compound 2; then compounds 3 and 1 (each within the scatter of the next).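

In this assay the first change seen on its own at this position, 4-methylthiophen-2-yl in place of 3-chlorothiophen-2-yl on a carbonyl carbon, comes with a 2.8-fold higher number from compound 2 to compound 3 (0.45 log units; beyond the scatter) and is thus a modest loss of strength. The position therefore responds to this exchange, even though the two groups have the same count of heavy atoms, the same five-membered aromatic ring with 1 hetero atom, and no net charge. Nothing at hand gives a reason for this step.

On these data alone, the step swaps the chlorine and the methyl group and moves the point of substitution in one exchange, so the share of each remains open. Also open, as far as these compounds go, is how an unsubstituted thiophen-2-yl, a furan-2-yl or a phenyl group would read on the same carbonyl carbon.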